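This account rests on a few compounds, and the source may have more. Where it says the series, first, only, none or still open, it means among the compounds named here.

The measured compounds:

compound 1 `O=C(O)c1ccccc1-c1ccc(CCc2ncc(CC3CCCCC3)[nH]2)cc1` gives 7.3 nM in an in vitro functional assay on cells for agonist activity at Bombesin receptor subtype-3 (Mus musculus), read by luminescence and calcium flux; on this read-out lower numbers stand for an effect already at smaller amounts and higher numbers for an effect only at larger amounts of compound
compound 2 `O=C(O)c1ccccc1-c1ccc(CCc2ncc(CC3CCC3)[nH]2)cc1` gives 7.1 nM in this assay
compound 3 `O=C(O)c1ccccc1-c1ccc(CCc2ncc(Cc3ccc(Cl)cc3)[nH]2)cc1` gives 102 nM in this assay

Compound 2 and compound 1 sit within the usual scatter of each other, as the step of a 1.0-fold lower number from compound 1 to compound 2 (0.01 log units; within the scatter) shows; both stand at the low end of these three numbers. Compound 3 stands well apart, as the step of a 14-fold higher number from compound 2 to compound 3 (1.16 log units; beyond the scatter) shows.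

Compound 4 `O=C(O)c1ccccc1-c1ccc(CCc2ncc(CCc3ccccc3)[nH]2)cc1` differs from compound 2 in one place: benzyl in place of cyclobutyl on a saturated chain carbon bound to an aromatic carbon. Among the measured compounds shown here, two measured steps bear on this change. Going from compound 2 to compound 3, and from compound 1 to compound 3, a saturated ring gave way to an aromatic ring on the same saturated chain carbon, and both steps were large: a 14-fold higher number from compound 2 to compound 3 (1.16 log units; beyond the scatter) and a 14-fold higher number from compound 1 to compound 3 (1.15 log units; beyond the scatter). The change to compound 4 likewise puts an aromatic ring where a saturated ring stood, though the aromatic ring here carries no chlorine and sits one carbon further out. A higher number beyond the scatter is therefore expected, as the estimated step of a 5.6-fold higher number from compound 2 to compound 4 (0.75 log units; beyond the scatter) expresses. Compound 4 is expected to give about 40 nM in this assay, with a range from 12 nM to 130 nM.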

Compound 4, half-maximal effective concentration: 174 nM
Compound 4: the middle estimate sits 4.4-fold (0.64 log units) below what was measured; measured number outside the range, above it.
By their numbers in this assay, from the lowest: compounds 2 and 1 (each within the scatter of the next); then compounds 3 and 4 (each within the scatter of the next).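

In compound 4, an aromatic ring again comes with a high number: the steps of a 25-fold higher number from compound 2 to compound 4 (1.39 log units; beyond the scatter) and a 24-fold higher number from compound 1 to compound 4 (1.38 log units; beyond the scatter) are both large, while a 1.7-fold higher number from compound 3 to compound 4 (0.23 log units; within the scatter) stays within the scatter. The chlorine of compound 3 is therefore not needed for the high number, since benzyl, which carries no chlorine, gives a value within the scatter of the one given by 4-chlorophenyl. Across these four compounds, the two with a saturated ring at this place give the low numbers and the two with an aromatic ring give the high numbers, and no compound goes against this split.

Nothing given here offers a reason for the split. Going by these compounds, compound 4 changes two things at once, ring type and chain length, as the cut from cyclobutylmethyl to phenethyl shows, so it remains open whether a cyclohexylethyl group, with a saturated ring on the longer chain, would keep the low number, and whether a pyridine ring or a simple amine at this place would side with the saturated or the aromatic groups.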